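Phenyl for methyl on the pyrrolidine ring of compound 3

The source may hold more compounds than are shown below. What is called first, only, known or untested is meant among the compounds shown, and "the series" means these compounds.

Compound 1 `Cc1ccccc1COc1ccc(N2CCC[C@H]2CC(=O)O)cc1` — 3400 nM
Compound 2 `Cc1ccccc1COc1ccc(N2CCC[C@H]2CC(=O)O)cc1C` — > 33000 nM
Compound 3 `Cc1ccccc1Cc1ccc(N2C[C@@H](C)C[C@H]2CC(=O)O)cc1` — 1100 nM

Three compounds sharing a core were tested in a functional assay on cells for agonist activity at Free fatty acid receptor 1 (Mus musculus), read by FLIPR and calcium flux, with a stated time of 100 s; on this read-out higher numbers stand for an effect only at larger amounts of compound and lower numbers for an effect already at smaller amounts. Compound 1 `Cc1ccccc1COc1ccc(N2CCC[C@H]2CC(=O)O)cc1` gives 3400 nM in this assay. For compound 2 `Cc1ccccc1COc1ccc(N2CCC[C@H]2CC(=O)O)cc1C` this assay reports only a limit, > 33000 nM. Compound 3 `Cc1ccccc1Cc1ccc(N2C[C@@H](C)C[C@H]2CC(=O)O)cc1` gives 1100 nM, the lowest of the two numbers shown; compound 1 is its nearest neighbour with a higher value.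

Going by the values given here, the single measured step, an at least 9.7-fold higher number from compound 1 to compound 2 (0.98 log units; beyond the scatter), concerns a methyl added to an aromatic carbon and runs up to a limit (the limit of > 33000 nM in this assay, at which 1 of the 3 values shown sits); it does not touch the saturated ring that is changed here.

Compound 4 `Cc1ccccc1Cc1ccc(N2C[C@@H](c3ccccc3)C[C@H]2CC(=O)O)cc1` differs from compound 3 by phenyl in place of methyl on a saturated ring carbon, a phenyl in place of methyl on a saturated ring carbon. Among the compounds with values here, no measured step bears on this change, so the expected step from compound 3 to compound 4 is a 1.4-fold higher number from compound 3 to compound 4 (0.13 log units; within the scatter), a small shift toward a higher number, within or near the scatter. Compound 4 is therefore estimated at 1500 nM in this assay, with a range from 400 nM to 6000 nM.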

Compound 4, half-maximal effective concentration: > 33000 nM
Compound 4: a limit, no number; the forecaster's own chance of this, stated with the estimate: 10%; middle value at least 22-fold (1.34 log units) away from the limit.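

In this assay, going by these compounds alone, phenyl in place of methyl on this saturated ring carbon gives an at least 30-fold higher number from compound 3 to compound 4 (1.47 log units; beyond the scatter), the first measured step on the saturated ring, since the earlier step concerned an aromatic carbon. With methyl at this carbon, two ring bonds from the ring nitrogen, compound 3 still gives a number, 1100 nM, whereas the phenyl change leaves no number to read, so this position responds strongly to the group it carries. Compound 4 reaches a limit of the assay and not a number: the limit of > 33000 nM in this assay, at which 2 of the 4 values shown sit.

The compounds shown leave open where between methyl and phenyl the change sets in, which an ethyl, a cyclopropyl or a hydroxyl group on this carbon would help to place. From the compounds shown here alone, whether phenyl at this carbon behaves the same way on the core of compound 1 also remains open.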